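Notes on compound 4: bromo in place of cyano

The compounds below may be only part of what the source reports. "The series", "measured", "known", "first", "only" and "open" are said of these compounds alone.

Measured in an ADME assay on a cell-free system (plasma, Homo sapiens) for metabolic stability, read by HPLC; on this read-out lower numbers stand for a shorter-lived compound and higher numbers for a longer-lived compound:
compound 1 `CN(/N=N/c1ccc(C#N)cc1)C(=O)CCc1ccc(O)cc1`: 2.99 h
compound 2 `CC(=O)c1ccc(/N=N/N(C)C(=O)NCCSc2ccc(O)cc2)cc1`: 61.6 h
compound 3 `Cc1ccc(/N=N/N(C)C(=O)NCCSc2ccc(O)cc2)cc1`: 88.5 h

Compound 1 gives the lowest of the three numbers in this assay; compound 2 and compound 3 both lie beyond the scatter above it. Among the compounds with values here, the only single-point step measured, a 1.4-fold higher number from compound 2 to compound 3 (0.16 log units; within the scatter), concerns a methyl in place of an acetyl on the core of compound 2 and does not touch the change considered here.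

Compound 4 `CN(/N=N/c1ccc(Br)cc1)C(=O)CCc1ccc(O)cc1` differs from compound 1 by bromo in place of cyano on an aromatic carbon. Within the data shown here, no measured pair shows a bromo in place of a cyano, so nothing in the data sets the size or direction of this step. The default expectation is therefore no change beyond the scatter, a step of a 1.0-fold higher number from compound 1 to compound 4 (0.00 log units; within the scatter). Compound 4 is estimated at 3 h, with a range of 1.5 h to 6 h.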

Compound 4, half-life: 8.3 h
Beside the measured number, compound 4's estimate is 2.8-fold (0.44 log units) below it, and the stated range ends below it.
By their numbers in this assay, from the lowest: compound 1; then compound 4; then compounds 2 and 3 (each within the scatter of the next).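

In this assay the aromatic carbon para to a large group proves responsive on the core of compound 1, with bromo in place of cyano giving a 2.8-fold higher number from compound 1 to compound 4 (0.44 log units; beyond the scatter). The earlier compounds shown here showed no change at this position on this core, and this single step now gives it a direction for one pair of groups. No available evidence explains the step.

As far as these compounds go, whether an amine or a carboxylic acid at this aromatic carbon would shift the half-life further remains open. Also open, from the compounds shown here alone, is whether bromo in place of cyano gives a similar step on other cores.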